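Butyl in place of isopropyl: notes on compound 3

This account rests on a few compounds, and the source may have more. Where it says the series, first, only, none or still open, it means among the compounds named here.

Measured so far in a functional assay on PC-3 cells (Homo sapiens) for cytotoxicity, read by sulforhodamine B assay, tested at 10 uM; on this read-out lower numbers stand for less inhibition and higher numbers for more inhibition at the one concentration tested (going by the name of the read-out):
compound 1 `CC(=O)OC[C@H]1O[C@@H](n2cc(-c3cc(C)no3)c(=O)[nH]c2=O)C[C@@H]1OC(C)=O`: 92.4%
compound 2 `CC(=O)OC[C@H]1O[C@@H](n2cc(-c3cc(-c4ccc(C(C)C)cc4)no3)c(=O)[nH]c2=O)C[C@@H]1OC(C)=O`: 50.3%

Going by the values given here, compound 2 gives the lower of the two numbers; the one step recorded, a number 42.1 percentage points lower from compound 1 to compound 2 (beyond the scatter), is large and beyond the scatter. Compound 3 `CCCCc1ccc(-c2cc(-c3cn([C@H]4C[C@H](OC(C)=O)[C@@H](COC(C)=O)O4)c(=O)[nH]c3=O)on2)cc1` is unmeasured and differs from compound 2 in one place: butyl in place of isopropyl on an aromatic carbon. Among the compounds with values here, no measured step swaps one alkyl chain for another on this aromatic carbon; the only step available exchanges methyl for 4-isopropylphenyl, a far larger change than the one from compound 2 to compound 3. That step is therefore only a loose guide and gives no direction for a change of chain shape at this position. Within the data shown here, with no bearing step, the expectation is no movement beyond the scatter, a number 2.3 percentage points lower from compound 2 to compound 3 (within the scatter). Compound 3 is accordingly estimated at 48%, with a range from 28% to 68%.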

Compound 3, a percentage reported as inhibition, at one concentration (the size of the read-out at that concentration, not a potency): 30.4%
Beside the measured number, compound 3's estimate is 17.6 percentage points above it; measured number inside the range.
By their numbers in this assay, from the lowest: compound 3; then compound 2; then compound 1.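

In this assay the alkyl group on the aromatic carbon, para to a large group, is not interchangeable: butyl for isopropyl gives a number 19.9 percentage points lower from compound 2 to compound 3 (beyond the scatter) and so moves the number beyond the scatter with no other part of the structure changed. Set against the methyl of compound 1, the 4-butylphenyl group gives a number 62 percentage points lower from compound 1 to compound 3 (beyond the scatter) as its overall step, so the fall seen with a phenyl-bearing group at this place depends on the alkyl group that phenyl carries and not on the phenyl alone. Nothing available explains why these two alkyl groups differ.

The compounds shown leave open whether a longer chain such as hexyl would lower the number further. They also leave open whether an amine or a carboxylic acid at the same aromatic carbon would raise it again toward the level of compound 1.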